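This account rests on a few compounds, and the source may have more. Where it says the series, first, only, none or still open, it means among the compounds named here.

Compound 1 `Oc1ccc(/C=N/Nc2nc3ccccc3s2)cc1O`: > 17500 nM
Compound 2 `CN(C)c1ccc(/C=N/Nc2nc3ccccc3s2)cc1`: > 16800 nM

Both of these figures come from a functional assay on HCT-8 cells (Homo sapiens) for cytotoxicity, read by MTT assay, with a stated time of 72 h (a lower number here means a stronger inhibitor, a higher number a weaker inhibitor), and neither is a true number: each is a limit of the assay, the point beyond which it does not report. Compound 2 therefore stands at the limit of > 16800 nM in this assay, at which 1 of the 2 values shown sits. Compound 1 stands at the limit of > 17500 nM in this assay, at which 1 of the 2 values shown sits. Among the compounds with values here, neither compound, then, has a measured potency, and no step between them can be counted.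

The next compound, compound 3 `Oc1ccc(/C=N/Nc2nc3ccccc3s2)cc1`, has not yet been measured in this assay. It is reached from compound 2 by a single change, (hydroxy in place of dimethylamino on an aromatic carbon).

Within the data shown here, because compound 2 sits at the limit of > 16800 nM in this assay, at which 1 of the 2 values shown sits, and no measured step is known, the step that the limit leaves unreadable from compound 2 to compound 3 is expected to be none beyond the scatter, with a fair chance that compound 3 also returns only a limit. Compound 3 is estimated at 20000 nM, within a range from 8000 nM to 60000 nM.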

Compound 3, half-maximal inhibitory concentration: > 18500 nM
Compound 3 was reported as a limit (the forecaster's own chance of this, stated with the estimate: 70%); the middle value lies beyond the limit too.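

In this assay, within the data shown here, compound 1, compound 2 and compound 3 each give only a limit, so no step among the three can be read. The compounds shown leave open how hydroxy, dimethylamino and hydrogen truly rank, and whether any change to the shared core yields a measurable potency.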